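Working notes: from compound 1 to compound 4

The source may report more compounds than this note shows. Statements on the series, on what has been measured and on what is new or still open speak of the compounds shown alone.

Measured so far:
compound 1 `O=C(Nc1nc(-c2cc3ccccc3o2)cs1)Nc1ccccc1F`: 2630 nM
compound 2 `O=C(Nc1ccccc1)Nc1nc(-c2cc3cc([N+](=O)[O-])ccc3o2)cs1`: 183000 nM
compound 3 `O=C(Nc1nc(-c2cc3cc(Br)ccc3o2)cs1)Nc1ccccc1F`: > 200000 nM
Not yet measured:
compound 4 `O=C(Nc1cccc(Cl)c1)Nc1nc(-c2cc3ccccc3o2)cs1`

Going by the values given here, in a physicochemical assay, with a stated time of 6 min (a higher number here means a weaker inhibitor, a lower number a stronger inhibitor), compound 1 gives 2630 nM, the lowest of the actual numbers so far, and compound 2 stands much higher at 183000 nM. Compound 3 gives only a limit, > 200000 nM, and not a number.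

The change under consideration is 3-chlorophenyl in place of 2-fluorophenyl on an amide-type nitrogen. Among the compounds with values here, the only measured step, an at least 76-fold higher number from compound 1 to compound 3 (1.88 log units; beyond the scatter), is large, but it is bromo in place of hydrogen on an aromatic carbon, and the 2-fluorophenyl stays in place. Within the data shown here, no measured step changes the group on the amide-type nitrogen alone, so the guidance is weak and the range must stay wide.

Among the measured compounds shown here, with compound 1 at 2630 nM as the lowest number so far, a moderate step to a higher number in this assay is expected, although a step within the scatter remains possible. The estimated step is a 1.9-fold higher number from compound 1 to compound 4 (0.28 log units; within the scatter). For compound 4 the expected value is 5000 nM, with an estimated range of 1000 nM to 30000 nM.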

Compound 4, half-maximal inhibitory concentration: 14100 nM
Compound 4: middle estimate off by 2.8-fold (0.45 log units), on the low side; measured number inside the range.
By their numbers in this assay, from the lowest: compound 1; then compound 4; then compound 2. At a limit, above all of these: compound 3.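

The group on the amide-type nitrogen now has a step of its own in this assay: 3-chlorophenyl in place of 2-fluorophenyl gives a 5.4-fold higher number from compound 1 to compound 4 (0.73 log units; beyond the scatter), a modest change at a position the earlier step did not touch. That earlier step, an at least 76-fold higher number from compound 1 to compound 3 (1.88 log units; beyond the scatter), kept the 2-fluorophenyl in place, so it said nothing about this position, whereas here the rest of compound 4 matches compound 1 and the group that enters has the same heavy-atom count as the one that leaves. Compound 3 carries a limit and not a number, so its step gives only a bound and its size cannot be set against this one: the limit of > 200000 nM in this assay, at which 1 of the 4 values shown sits.

This single change alters both the halogen and its place on the ring, and the compounds shown do not separate the two. Also open, from the compounds shown here alone, is how this position responds to groups of another kind, such as an amine or a carboxylic acid on the ring, or a longer chain in place of the ring.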